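Bromo placement on the phenyl ring of the shared core

The compounds below may be only part of what the source reports. "The series", "measured", "known", "first", "only" and "open" are said of these compounds alone.

The parent of the pair, compound 1 `c1ccc(-c2nnc(Nc3ncccn3)o2)cc1`, is assessed in a functional assay, with a stated time of 30 min, tested at 20 uM (on this read-out lower numbers stand for less inhibition and higher numbers for more inhibition at the one concentration tested (going by the name of the read-out)), where compound 1 gives 51.4%. Among the two numbers measured so far this is the higher one; its nearest neighbour is compound 2 `Brc1ccc(-c2nnc(Nc3ncccn3)o2)cc1`, which in this assay gives 47.8%. For the measured compounds named here, the one step recorded, a number 3.6 percentage points lower from compound 1 to compound 2 (within the scatter), is within the scatter and involves bromo in place of hydrogen on an aromatic carbon.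

Compound 3 `Brc1cccc(-c2nnc(Nc3ncccn3)o2)c1` differs from compound 1 by bromo in place of hydrogen on an aromatic carbon. Going by the values given here, the only measured step that bears on this change is the one from compound 1 to compound 2, which was within the scatter, so no step beyond the scatter is expected here either: the estimated step is a number 3.4 percentage points lower from compound 1 to compound 3 (within the scatter). Compound 3 is therefore expected to give about 48% in this assay, with a likely range from 30% to 65%.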

Compound 3, a percentage reported as inhibition, at one concentration (the size of the read-out at that concentration, not a potency): 47.9%
Compound 3: middle estimate off by 0.1 percentage points, on the high side; measured number inside the range.
By their numbers in this assay, from the lowest: compounds 2, 3 and 1 (each within the scatter of the next).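

In this assay, for the compounds shown here, placing bromo meta to a large group gives a number 3.5 percentage points lower from compound 1 to compound 3 (within the scatter), so a second ring carbon now joins the one in compound 2 in showing no step beyond the scatter for this change. The place of the bromo makes no readable difference in this pair: compound 2 gives 47.8% and compound 3 gives 47.9%, values within the scatter of each other. No measurement is available that offers a reason for this result.

Still open, on these data alone, is whether a group other than bromo on this ring, such as an amine, a carboxylic acid or a longer chain, would produce a step beyond the scatter. Also open, as far as these compounds go, is how changes elsewhere on the shared core would read in this assay.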